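Swapping a pyrazinyl for a pyridyl on a dimethylated core

This account rests on a few compounds, and the source may have more. Where it says the series, first, only, none or still open, it means among the compounds named here.

Measured compounds:
Compound 1: `O=C1CCCC2=C1C(c1ccc(F)cc1Cl)N=C(c1cnccn1)N2` with 777000 nM
Compound 2: `O=C1CCCC2=C1C(c1ccc(F)cc1Cl)N=C(c1cccnc1)N2` with 82800 nM
Compound 3: `CC1(C)CC(=O)C2=C(C1)NC(c1cnccn1)=NC2c1ccc(F)cc1Cl` with 773000 nM

The three compounds were tested in an ADME assay on HepG2 2.2.15 cells (Homo sapiens) for cytotoxicity; on this read-out higher numbers stand for weaker inhibition and lower numbers for stronger inhibition. Compound 1 and compound 2 share one core; compound 3 has a core that carries two methyl groups, and the difference between the two cores is not broken down here. In this assay compound 3 gives 773000 nM, and compound 1 gives 777000 nM, two numbers that lie within the scatter of each other, so no order is drawn between them.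

One change is seen on the first core: pyridin-3-yl in place of pyrazin-2-yl on a carbon with a double bond to nitrogen. This brought a 9.4-fold lower number from compound 1 to compound 2 (0.97 log units; beyond the scatter), a step beyond the scatter.

Compound 4, `CC1(C)CC(=O)C2=C(C1)NC(c1cccnc1)=NC2c1ccc(F)cc1Cl`, is not yet measured. It differs from compound 3 by pyridin-3-yl in place of pyrazin-2-yl on a carbon with a double bond to nitrogen. The place of the change is described in identical words for both pairs, so the change from compound 3 to compound 4 is the same as that from compound 1 to compound 2. Because compound 1 gives 777000 nM and compound 3 gives 773000 nM, the step is expected to repeat at about the same size, which would be a 9.1-fold lower number from compound 3 to compound 4 (0.96 log units; beyond the scatter). Compound 4 is therefore estimated to give 85000 nM in this assay, expected to fall between 30000 nM and 250000 nM; this rests on two compounds only and the pattern is unproven beyond them.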

Compound 4, half-maximal inhibitory concentration: 624000 nM
Beside the measured number, compound 4's estimate is 7.3-fold (0.87 log units) below it; the whole stated range lies below it.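

On the core that carries two methyl groups, pyridin-3-yl in place of pyrazin-2-yl gave a 1.2-fold lower number from compound 3 to compound 4 (0.09 log units; within the scatter), so in this assay no difference can be claimed between these two compounds. Among these compounds, the replacement therefore did not carry over from one core to the other at the size seen on the first core, and the two steps differ by more than repeated measurements would explain: the same change on two cores in this assay, a 9.4-fold lower number (0.97 log units; beyond the scatter) from compound 1 to compound 2 and a 1.2-fold lower number (0.09 log units; within the scatter) from compound 3 to compound 4, 7.6-fold (0.88 log units) apart, beyond the scatter of two such steps This shows that, across these four compounds, the outcome of this swap cannot be taken from one core to the other, but it does not show which feature of the cores sets the two steps apart, nor how the swap would behave on any further core, since the evidence is only two pairs of compounds.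

The compounds shown leave open whether a core with a single methyl group, or with an ethyl group in place of the two methyl groups, would follow the step seen on the first core or the one seen on the dimethylated core. They also leave open whether other groups on the carbon with a double bond to nitrogen, such as pyridin-4-yl, pyrimidin-5-yl or an open-chain amine, would show the same dependence on the core.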